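The source may report more compounds than this note shows. Statements on the series, on what has been measured and on what is new or still open speak of the compounds shown alone.

Of the compounds shown here, two have so far been measured in a functional assay on K562 cells (Homo sapiens) for antiproliferative activity, read by sulforhodamine B assay, with a stated time of 48 h; a higher number here means a weaker inhibitor of growth, a lower number a stronger inhibitor of growth. Compound 1 `COc1ccc(OC)c(/C=C/c2nnc(Nc3ccc(Cl)cc3)o2)c1` gives 92800 nM in this assay, whereas compound 2 `COc1ccc(OC)c(/C=C/C(=O)N/N=C/c2ccc(Cl)cc2)c1` gives 48.8 nM. Going by the values given here, compound 2 therefore holds the lowest of the two numbers, and the only other value, that of compound 1, lies far above it, beyond the scatter. Among the compounds with values here, the two structures differ in more than one place, so no single step connects them. Compound 3 `COc1ccc(OC)c(/C=C/C(=O)N/N=C/c2ccccc2)c1` is the next compound to be measured. It differs from compound 2 by hydrogen in place of chloro on an aromatic carbon, which, read one bond further out, is the change from 4-chlorophenyl to phenyl, para to a large group. Within the data shown here, no step of this kind has been measured here. The step is expected to be small, toward a somewhat higher number or none beyond the scatter, giving a 2.0-fold higher number from compound 2 to compound 3 (0.31 log units; beyond the scatter). Compound 3 is accordingly estimated at 100 nM in this assay, with a range from 35 nM to 300 nM.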

Compound 3, concentration for 50% growth inhibition: 488 nM
Compound 3: the middle estimate sits 4.9-fold (0.69 log units) below what was measured, and the stated range ends below it.
By their numbers in this assay, from the lowest: compound 2; then compound 3; then compound 1.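

In this assay, going by these compounds alone, the change from 4-chlorophenyl to phenyl, para to a large group, gives a 10-fold higher number from compound 2 to compound 3 (1.00 log units; beyond the scatter) and is the first change in one place that can be read on its own. It shows that the chloro on this aromatic carbon is not silent: with hydrogen there, growth inhibition is clearly weaker, though compound 3 still has a far lower number than compound 1. Nothing among the data shown accounts for the size of this step.

Going by these compounds, whether fluoro, bromo, methoxy or an amine on this carbon would keep the number of compound 2 or move it toward that of compound 3 remains open. This single step also leaves open whether the same change would read alike on the core of compound 1.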